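Compound 2 to compound 3: exchange on the shared core

This account rests on a few compounds, and the source may have more. Where it says the series, first, only, none or still open, it means among the compounds named here.

In an in vivo ADME assay on the whole organism for pharmacokinetics, with Rattus norvegicus as the target (on this read-out lower numbers stand for narrower distribution and higher numbers for wider distribution into tissues), compound 1 (`CC(C)c1onc(COc2c(Cl)cc(F)cc2Cl)c1COc1ccc(/C=C/c2cccc(C(=O)O)c2)c(Cl)c1`) gives 1.4 L/kg and compound 2 (`CC(C)c1onc(-c2c(Cl)cncc2Cl)c1COc1ccc(/C=C/c2cccc(C(=O)O)c2)c(Cl)c1`) gives 1.1 L/kg as its value. The two cannot be told apart, since a 1.3-fold lower number from compound 1 to compound 2 (0.10 log units; within the scatter) is all that separates them, so compound 2 stands level with compound 1.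

The change to compound 3 (`CC(C)c1onc(COc2c(Cl)cccc2Cl)c1COc1ccc(/C=C/c2cccc(C(=O)O)c2)c(Cl)c1`) is (2,6-dichlorophenoxy)methyl in place of 3,5-dichloropyridin-4-yl on an aromatic carbon and puts (2,6-dichlorophenoxy)methyl in place of 3,5-dichloropyridin-4-yl on an aromatic carbon, next to the ring nitrogen. For the measured compounds named here, the one measured step bearing on this is a 1.3-fold lower number from compound 1 to compound 2 (0.10 log units; within the scatter) at the same place, where 3,5-dichloropyridin-4-yl took the place of (2,6-dichloro-4-fluorophenoxy)methyl. The group entering in compound 3 differs from that group only by the missing fluoro substituent, and no measurement isolates that difference. Read in reverse, the step offers no ground for a shift beyond the scatter, though a single pair is thin support. The expected step is a 1.2-fold higher number from compound 2 to compound 3 (0.07 log units; within the scatter) and would stay within the scatter. For compound 3 the estimate is 1.3 L/kg with an expected range from 0.75 L/kg to 2.2 L/kg overall.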

Compound 3, volume of distribution at steady state: 1.2 L/kg
Compound 3: middle estimate off by 1.1-fold (0.03 log units), on the high side, and the stated range covers the measured number.
By their numbers in this assay, from the lowest: compounds 2, 3 and 1 (each within the scatter of the next).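

Working notes on the position next to the ring nitrogen: in this assay, the exchange of 3,5-dichloropyridin-4-yl for (2,6-dichlorophenoxy)methyl leaves the read-out within the scatter (a 1.1-fold higher number from compound 2 to compound 3 (0.04 log units; within the scatter)), so the two groups cannot be told apart here, just as the fluorinated phenoxymethyl group and 3,5-dichloropyridin-4-yl could not be separated before. The new pair also isolates the fluoro substituent that no earlier comparison could address, and hydrogen in its place gives a step that is again within the scatter (a 1.2-fold lower number from compound 1 to compound 3 (0.07 log units; within the scatter)), so all three compounds stand level and this fluoro substituent shows no measurable effect on the read-out. No measured information on the compounds offers an explanation for this levelness.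

As far as these compounds go, all three groups at this position carry two chlorines on a six-membered aromatic ring, so it remains open whether a group of another kind, such as an aminomethyl group, a carboxylic acid or a longer alkyl chain, would move the read-out beyond the scatter. From the compounds shown here alone, the isopropyl group and the carboxylic acid of the shared core stay constant throughout, so their bearing on the read-out also remains open.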